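Adding a Chloro to the Benzyl Arm of Compound 3

The compounds below may be only part of what the source reports. "The series", "measured", "known", "first", "only" and "open" are said of these compounds alone.

Compound 1, `Cc1ccc(CSc2cc(Cl)c(C)cc2S(=O)(=O)/N=C(\N)n2nc(C)cc2-c2ccccc2)cc1`: 0.176 h
Compound 2, `Cc1cccc(CSc2cc(Cl)c(C)cc2S(=O)(=O)/N=C(\N)n2nc(C)cc2-c2ccccc2)c1`: 0.214 h
Compound 3, `Cc1cc(-c2ccccc2)n(/C(N)=N/S(=O)(=O)c2cc(C)c(Cl)cc2SCc2ccccc2)n1`: 0.0938 h

The three compounds share one core and were all measured in an ADME assay on microsomes from liver (Homo sapiens) for metabolic stability, read by LC-MS, using NADPH, tested at 5 uM; on this read-out higher numbers stand for a longer-lived compound and lower numbers for a shorter-lived compound. Compound 3 has the lowest number of the three: the gap to compound 1, a 1.9-fold lower number from compound 1 to compound 3 (0.27 log units; within the scatter), stays within the scatter, while the gap to compound 2, a 2.3-fold lower number from compound 2 to compound 3 (0.36 log units; beyond the scatter), lies beyond it. Compound 4, `Cc1cc(-c2ccccc2)n(/C(N)=N/S(=O)(=O)c2cc(C)c(Cl)cc2SCc2ccc(Cl)cc2)n1`, differs from compound 3 by chloro in place of hydrogen on an aromatic carbon. Going by the values given here, no measured step changes that ring in the same way. The closest guide is the move of a methyl on the benzyl ring, a 1.2-fold higher number from compound 1 to compound 2 (0.08 log units; within the scatter), which stayed within the scatter. A step of similar small size, with no clear direction, is therefore expected in this assay: a 1.1-fold higher number from compound 3 to compound 4 (0.03 log units; within the scatter). Compound 4 is estimated at 0.1 h, between 0.05 h and 0.2 h.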

Compound 4, half-life: 0.24 h
The estimate for compound 4 lay 2.4-fold (0.38 log units) below the measured number, outside the stated range (above it).
By their numbers in this assay, from the lowest: compounds 3, 1, 2 and 4 (each within the scatter of the next, the first and the last beyond it).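

Chloro in place of hydrogen on the benzyl ring gives a 2.6-fold higher number from compound 3 to compound 4 (0.41 log units; beyond the scatter) in this assay and so shows that this ring carbon can shift the number, which the small methyl move had not suggested. Chloro is not set apart from the methyl-bearing arms, since a 1.4-fold higher number from compound 1 to compound 4 (0.13 log units; within the scatter) and a 1.1-fold higher number from compound 2 to compound 4 (0.05 log units; within the scatter) both stay within the scatter. Nothing measured here explains the step. On these data alone, whether fluoro, bromo or methoxy on the same carbon would act like chloro stays open. So does whether chloro on another carbon of that ring would give a step of similar size.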